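From a propargyl to an allyl side chain

The source may report more compounds than this note shows. Statements on the series, on what has been measured and on what is new or still open speak of the compounds shown alone.

compound 1 `Cc1cc(Nc2cc(-c3ccccc3)[nH]n2)n2nc(SCc3ccc(Br)cc3)nc2n1` gives 39300 nM
compound 2 `Cc1cc(Nc2cc(-c3ccccc3)[nH]n2)n2nc(SCC(=O)c3ccccc3)nc2n1` gives 33300 nM
compound 3 `C#CCSc1nc2nc(C)cc(Nc3cc(-c4ccccc4)[nH]n3)n2n1` gives 45700 nM

These three compounds share one core and differ only in the group on a saturated chain carbon bound to a sulfur. In an ADME assay on GES1 cells (Homo sapiens) for inhibition, read by MTT assay, with a stated time of 72 h (on this read-out higher numbers stand for weaker inhibition and lower numbers for stronger inhibition), compound 3 gives 45700 nM and has no clear rank among the three. The comparison with its neighbours shows a 1.2-fold higher number from compound 1 to compound 3 (0.07 log units; within the scatter) and also a 1.4-fold higher number from compound 2 to compound 3 (0.14 log units; within the scatter) so both gaps are small against the normal spread of repeated measurements.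

The open question is compound 4 `C=CCSc1nc2nc(C)cc(Nc3cc(-c4ccccc4)[nH]n3)n2n1` which has vinyl in place of ethynyl on a saturated chain carbon bound to a sulfur and stays otherwise identical to compound 3. Among the measured compounds shown here, no measurement yet tests this exact swap, and no vinyl compound has been measured. The nearest evidence is the other changes at the same place. Besides the two steps above, the data show a 1.2-fold lower number from compound 1 to compound 2 (0.07 log units; within the scatter) so even replacing one whole group with a quite different one has not moved the number beyond the scatter. The same is therefore expected here in this assay with no favoured direction. The expected step is a 1.1-fold lower number from compound 3 to compound 4 (0.04 log units; within the scatter) and it should stay within the scatter. Compound 4 is estimated at 42000 nM with an expected range from 24000 nM to 70000 nM in this assay once it is measured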

Compound 4, half-maximal inhibitory concentration: > 50000 nM
Compound 4: only a limit was reported (the forecaster's own chance of this, stated with the estimate: 15%); middle value at least 1.1-fold (0.07 log units) from the limit.
By their numbers in this assay, from the lowest: compounds 2, 1 and 3 (each within the scatter of the next). At a limit, above all of these: compound 4.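

In this assay compound 4 is reported only as a limit, > 50000 nM, and not as an exact number. The change from ethynyl to vinyl, a swap of two carbons for two carbons with a triple bond becoming a double bond, therefore yields only floors for the steps: an at least 1.0-fold higher number from compound 3 to compound 4 (0.03 log units; that floor lies within the scatter), an at least 1.5-fold higher number from compound 2 to compound 4 (0.17 log units; that floor lies within the scatter) and an at least 1.2-fold higher number from compound 1 to compound 4 (0.10 log units; that floor lies within the scatter). All three floors fall within the scatter, so this position has still not shown a measured difference beyond it, but compound 4 is the first compound here to reach a limit instead of giving a number: the limit of > 50000 nM in this assay, at which 1 of the 4 values shown sits.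

As far as these compounds go, how far compound 4 really lies from the other three stays open, and with it the question of whether vinyl and ethynyl differ by more than the scatter in this assay. Also open, from the compounds shown here alone, is what an amine, a carboxylic acid or a longer saturated chain would do on a saturated chain carbon bound to a sulfur, with the shared core left unchanged.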